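Chalcone-pyrazole hybrids: swapping the aryl ketone substituent

A few compounds are considered here, and "the series" means these few. Any claim that something is new, unique, unknown or untested is made for them only; others in the source may bear on it.

The study examines cytotoxicity in a functional assay on HCT-15 cells (Homo sapiens) for cytotoxicity, read by sulforhodamine B assay, with a stated time of 48 h, tested at 1 uM (on this read-out lower numbers stand for a stronger effect and higher numbers for a weaker effect at the one concentration tested), for a small set of chalcone-type pyrazoles. Compound 1 `COc1ccc(-c2cc(/C=C/C(=O)c3ccc(N)cc3)[nH]n2)cc1` gives 50% in this assay. Compound 2 `COc1cc(-c2cc(/C=C/C(=O)c3ccc(Cl)c(Cl)c3)[nH]n2)cc(OC)c1OC` gives 86% in this assay, the highest of the two numbers, and its nearest neighbour, compound 1, sits lower by a gap beyond the usual scatter, so compound 2 shows the weaker effect of the two measured compounds.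

Compound 3 `COc1ccc(C(=O)/C=C/c2cc(-c3cc(OC)c(OC)c(OC)c3)n[nH]2)cc1` has not yet been measured. It differs from compound 2 in one place: 4-methoxyphenyl in place of 3,4-dichlorophenyl on a carbonyl carbon. For the measured compounds named here, no measured pair isolates this change, so the size of its effect is unknown. A step from compound 2 downward, of moderate size, is expected in this assay, though a step within the scatter cannot be ruled out. For compound 3 the estimated value is 72%, with a range from 45% to 100%, which corresponds to an expected step of a number 14 percentage points lower from compound 2 to compound 3 (beyond the scatter).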

Compound 3, a percentage reported as activity, at one concentration (the size of the read-out at that concentration, not a potency): 72%
The estimate for compound 3 equals the measured number at the digits printed, within the range that was stated.
By their numbers in this assay, from the lowest: compound 1; then compound 3; then compound 2.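

In this assay, for the compounds shown here, the change gives the first step in this set that can be read in one place: a number 14 percentage points lower from compound 2 to compound 3 (beyond the scatter). It shows that the group on a carbonyl carbon influences the read-out with the rest of the molecule unchanged, and that 4-methoxyphenyl in place of 3,4-dichlorophenyl gives a modestly stronger effect at the one concentration tested. No measurement shown here explains the step, which brings in an oxygen and a hydrogen-bond acceptor and removes both chlorine atoms.

A single pair cannot separate those differences or show how an amine or a carboxylic acid on that aryl ring would behave. Compound 1 differs from compound 2 and compound 3 in more than one place, so its steps to them cannot be read.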